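From Trifluoromethoxy to Acetamido: Expecting Another Cytotoxicity Limit

The source may report more compounds than this note shows. Statements on the series, on what has been measured and on what is new or still open speak of the compounds shown alone.

Compound 1 `CCOC(=O)c1c(-c2cccc(OC)c2)[nH]c2cc(OC)ccc2c1=O` and compound 2 `CCOC(=O)c1c(-c2cccc(OC(F)(F)F)c2)[nH]c2cc(OC)ccc2c1=O` share one core and differ only by trifluoromethyl in place of methyl on an oxygen on an aromatic ring. In an ADME assay on Raji cells (Homo sapiens) for cytotoxicity, read by luminescence, with a stated time of 72 h (a higher number here means that more compound is needed for the effect, a lower number that less compound is needed), compound 1 gives only a limit, > 21500 nM. In this assay compound 2 also gives only a limit, > 21500 nM. The step that the two limits leave unreadable from compound 1 to compound 2 stays unreadable because of the limit of > 21500 nM in this assay, at which 2 of the 2 values shown sit. Compound 3 `CCOC(=O)c1c(-c2cccc(NC(C)=O)c2)[nH]c2cc(OC)ccc2c1=O` carries acetamido in place of trifluoromethoxy on an aromatic carbon. Within the data shown here, no measured step bears on this change, so no direction beyond the scatter can be expected. Compound 3 is therefore estimated at 30000 nM, between 10000 nM and 100000 nM. The expected step is a step that the limit leaves unreadable from compound 2 to compound 3.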

Compound 3, half-maximal effective concentration: > 21500 nM
Compound 3 ended at the assay's limit; the forecaster's own chance of this, stated with the estimate: 75%; the middle value is on the limit's open side.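

Among these compounds, no step among compound 1, compound 2 and compound 3 can be read, because each value is a limit and not a number: the limit of > 21500 nM in this assay, at which 3 of the 3 values shown sit. From the compounds shown here alone, whether methoxy, trifluoromethoxy and acetamido differ at all in the concentration needed for the effect stays open.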